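Trifluoromethyl for methoxy at the assay limit

The source may report more compounds than this note shows. Statements on the series, on what has been measured and on what is new or still open speak of the compounds shown alone.

Compound 1 `C=CCc1cc(-c2ccccc2)ccc1O`: > 100000 nM
Compound 2 `C=CCc1cc(-c2ccc(C(F)(F)F)cc2)ccc1OC`: > 100000 nM
Compound 3 `C=CCc1cc(-c2ccc(OC)cc2)ccc1O`: > 100000 nM

All three compounds were tested in a functional assay on A549 cells (Homo sapiens) for antiproliferative activity, read by MTT assay, with a stated time of 24 h (on this read-out higher numbers stand for weaker inhibition and lower numbers for stronger inhibition), and each result is a limit of the assay and not a number. Within the data shown here, the series so far rests entirely on (the limit of > 100000 nM in this assay, at which 3 of the 3 values shown sit). Compound 3 gives > 100000 nM, which is such a limit, so it has no measured position relative to the others.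

Compound 4 `C=CCc1cc(-c2ccc(C(F)(F)F)cc2)ccc1O` is the next case, with trifluoromethyl in place of methoxy on an aromatic carbon. Among the measured compounds shown here, the one measured step that bears on this change is a step that the two limits leave unreadable from compound 1 to compound 3, where methoxy replaces hydrogen, and it offers no size to carry over. Compound 2 also carries trifluoromethyl and gives > 100000 nM, again a limit.

Nothing measured points in either direction, so compound 4 is expected to remain at the limit in this assay. The expected step is a number no higher from compound 3 to compound 4 (the limit leaves the size open). Compound 4 is estimated at 100000 nM, with an expected range of 40000 nM to 250000 nM.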

Compound 4, half-maximal inhibitory concentration: 76000 nM
Beside the measured number, compound 4's estimate is 1.3-fold (0.12 log units) above it; measured number inside the range.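

With trifluoromethyl in place of methoxy on an aromatic carbon, para to a large group, the series reaches its first number instead of a limit in this assay, and the change gives an at least 1.3-fold lower number from compound 3 to compound 4 (0.11 log units; that floor lies within the scatter). Hydrogen in place of methyl on the oxygen gives an at least 1.3-fold lower number from compound 2 to compound 4 (0.11 log units; that floor lies within the scatter), and trifluoromethyl in place of hydrogen gives an at least 1.3-fold lower number from compound 1 to compound 4 (0.11 log units; that floor lies within the scatter), so all three floors lie within the scatter and none establishes a real gain. The comparison therefore remains bounded on one side throughout the series: the limit of > 100000 nM in this assay, at which 3 of the 4 values shown sit.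

Going by these compounds, whether any group at this position can move the number beyond the scatter stays open. An amine or a carboxylic acid in place of trifluoromethyl would test this on the same core.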